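The compounds below may be only part of what the source reports. "The series", "measured", "known", "first", "only" and "open" are said of these compounds alone.

Measured so far in an assay on isolated protein for binding affinity to 5-hydroxytryptamine receptor 3A (Homo sapiens); on this read-out higher numbers stand for weaker inhibition and lower numbers for stronger inhibition:
- compound 1 `Cc1cccc(-c2n[nH]cc2N2CCCNCC2)c1` gives 816 nM
- compound 2 `Clc1ccc(-c2n[nH]cc2N2CCCNCC2)cc1` gives 498 nM
- compound 3 `COc1ccccc1-c1n[nH]cc1N1CCCNCC1` gives 2230 nM

Compound 3 carries the highest number of the three, which on this read-out means the weakest binding. Compound 1 sits below it by a gap beyond the usual scatter, and compound 2 sits lower still. Compound 4 `c1ccc(-c2n[nH]cc2N2CCCNCC2)cc1` differs from compound 3 in one place: hydrogen in place of methoxy on an aromatic carbon. Within the data shown here, no measured pair shows this particular change, so its effect is not known from the data. Since compound 1 and compound 2, which carry other small groups on that ring, both show lower numbers than compound 3, a modest drop in the number is expected for compound 4, a step of about a 2.8-fold lower number from compound 3 to compound 4 (0.45 log units; beyond the scatter). Compound 4 is therefore estimated at 800 nM, within a range from 300 nM to 2000 nM.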

Compound 4, inhibition constant: 2100 nM
Beside the measured number, compound 4's estimate is 2.6-fold (0.42 log units) below it; measured number outside the range, above it.
By their numbers in this assay, from the lowest: compounds 2 and 1 (each within the scatter of the next); then compounds 4 and 3 (each within the scatter of the next).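

In this assay, taking the methoxy off leaves the number in place (a 1.1-fold lower number from compound 3 to compound 4 (0.03 log units; within the scatter)), so at this spot, ortho to a large group, methoxy and hydrogen cannot be told apart. Compound 4 also serves as a bare reference: replacing chloro with hydrogen gives a clear loss (a 4.2-fold higher number from compound 2 to compound 4 (0.62 log units; beyond the scatter)), and replacing methyl with hydrogen gives a smaller one (a 2.6-fold higher number from compound 1 to compound 4 (0.41 log units; beyond the scatter)). Nothing measured here explains these differences. Still open, as far as these compounds go, is whether chloro or methyl would lower the number at the methoxy position. An amine or a carboxylic acid on the ring is also untested in the compounds shown.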